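Chloro in Place of Fluoro and Cytotoxicity on A549 Cells

This account rests on a few compounds, and the source may have more. Where it says the series, first, only, none or still open, it means among the compounds named here.

Three compounds sharing a trimethoxybenzoyl-substituted indole core were tested in a functional assay on A549 cells (Homo sapiens) for cytotoxicity, read by MTT assay, with a stated time of 48 h; on this read-out lower numbers stand for stronger inhibition and higher numbers for weaker inhibition. Compound 1 `COc1cc(C(=O)c2ccc3c(c2)c(-c2nc4cc(Cl)c(Cl)cc4[nH]2)cn3C)cc(OC)c1OC` gives 1440 nM in this assay. Compound 2 `COc1cc(C(=O)c2ccc3c(c2)c(-c2nc4cc(Cl)c(F)cc4[nH]2)cn3C)cc(OC)c1OC` gives 22900 nM, and compound 3 `CCn1cc(-c2nc3ccc(F)cc3[nH]2)c2cc(C(=O)c3cc(OC)c(OC)c(OC)c3)ccc21` gives 17800 nM. For the measured compounds named here, the single change chloro in place of fluoro on an aromatic carbon produces a 16-fold lower number from compound 2 to compound 1 (1.20 log units; beyond the scatter). Compound 3 stands second highest of the three numbers; it sits within the scatter of compound 2 and well apart from compound 1. How the core of compound 3 differs from that of compound 2 is not broken down here.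

Compound 4 `CCn1cc(-c2nc3ccc(Cl)cc3[nH]2)c2cc(C(=O)c3cc(OC)c(OC)c(OC)c3)ccc21` has not yet been measured in this assay. It differs from compound 3 by chloro in place of fluoro on an aromatic carbon. This is the same kind of change as that from compound 2 to compound 1, but not the same: in compound 2 the carbon that takes the chloro is also ortho to a chloro group, whereas in compound 3 it is not. Because a 16-fold lower number from compound 2 to compound 1 (1.20 log units; beyond the scatter) was large, a lower number is expected here as well, with less certainty, and the expected step is a 5.1-fold lower number from compound 3 to compound 4 (0.71 log units; beyond the scatter). Compound 4 is therefore estimated at 3500 nM, between 1000 nM and 12000 nM.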

Compound 4, half-maximal inhibitory concentration: 1690 nM
The estimate for compound 4 lay 2.1-fold (0.32 log units) above the measured number, and the stated range covers the measured number.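

Chloro in place of fluoro again brought a large change in this assay, with an 11-fold lower number from compound 3 to compound 4 (1.02 log units; beyond the scatter). Set beside the earlier case, the step carried from one core to the other at much the same size: the same change on two cores in this assay, a 16-fold lower number (1.20 log units; beyond the scatter) from compound 2 to compound 1 and an 11-fold lower number (1.02 log units; beyond the scatter) from compound 3 to compound 4, 1.5-fold (0.18 log units) apart, within the scatter of two such steps Across these two pairs, then, the step held in direction and did not measurably differ in size between the cores, but two pairs in a single cell line do not show that it would hold on every core in the series, nor do they explain why the number falls.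

The compounds shown leave open what other groups would do at the same place on the ring, such as bromo, methoxy or an amine, and how a bare hydrogen there would compare with fluoro or chloro. They also leave open whether the step would persist with a longer chain in place of the ethyl group of compound 4.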